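Moving from a propyl ester to a diethyl amide

The source may report more compounds than this note shows. Statements on the series, on what has been measured and on what is new or still open speak of the compounds shown alone.

Compound 2 `CCCOC(=O)/C=C(C)/C=C/CC(C)CCCC(C)(C)OC` has been measured in a physicochemical assay for lipophilicity (on this read-out lower numbers stand for lower lipophilicity and higher numbers for higher lipophilicity), where compound 2 gives 6.08. Among the three compounds measured, compound 2 sits second highest. Going by the values given here, compound 1 `CCCOC(=O)/C=C(C)/C=C/CC(C)CCCC(C)C` is the nearest-built neighbour, and compound 1 gives 7.28; the step of a number 1.20 log units lower from compound 1 to compound 2 (beyond the scatter) is the only measured step available. Compound 3 `CC(=O)OC(C)(C)CCCC(C)C/C=C/C(C)=C/C(=O)OC(C)C` gives 5.98, and compound 3 differs from compound 2 by less than the scatter, so nothing can be read from that pair beyond the two values themselves.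

Compound 4 `CCN(CC)C(=O)/C=C(C)/C=C/CC(C)CCCC(C)(C)OC` differs from compound 2 in one place: diethylamino in place of propoxy on a carbonyl carbon. Among the compounds with values here, no measured step exchanges an ester for an amide, so the measured step from compound 1 to compound 2, which concerns a methoxy on the chain, bears on it only loosely. The expectation is that compound 4 moves to a lower value in this assay by a number 0.78 log units lower from compound 2 to compound 4 (beyond the scatter). Compound 4 is therefore estimated at 5.3, expected to fall between 4.7 and 5.9.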

Compound 4, partition coefficient: 4.82
Estimate against measurement, compound 4: 0.48 log units above, and the stated range covers the measured number.
By their numbers in this assay, from the lowest: compound 4; then compounds 3 and 2 (each within the scatter of the next); then compound 1.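

The earlier compounds shown here showed a large change only at the far end of the chain, but the carbonyl carbon also responds in this assay: diethylamino in place of propoxy gives a number 1.26 log units lower from compound 2 to compound 4 (beyond the scatter) and so joins a number 1.20 log units lower from compound 1 to compound 2 (beyond the scatter) as a second large step. The number falls even though the entering diethylamino has 5 heavy atoms against 4 for the leaving propoxy, so heavy-atom count alone does not set the order of this pair. Nothing available explains the size of this step.

The compounds shown leave open whether the same exchange would give a similar step on the core of compound 1, which lacks the methoxy. They also leave open how a dimethylamino group or a carboxylic acid on this carbonyl carbon would read in this assay.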